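The compounds below may be only part of what the source reports. "The series", "measured", "known", "first", "only" and "open" are said of these compounds alone.

Measured so far in a functional assay on a cell-free system (plasma) for inhibition of platelet-activating factor acetylhydrolase (Homo sapiens), tested at 100 nM; a higher number here means more inhibition at the concentration tested (going by the name of the read-out), a lower number less inhibition:

- compound 1, `CCCCCCCCN(C)C(=O)Cn1cc(Cc2cnc(OCC)nc2)c(=O)nc1SCc1ccc(F)cc1`, gives 23%
- compound 2, `CCCCCCCCN(C)C(=O)Cn1cc(Cc2cnc(=O)n(CC)c2)c(=O)nc1SCc1ccc(F)cc1`, gives 48%
- compound 3, `CCCCCCCCN(C)C(=O)Cn1cc(Cc2cnc(=O)n(CC(=O)O)c2)c(=O)nc1SCc1ccc(F)cc1`, gives 56%

Compound 3 holds the highest of the three numbers, but only one of its separations counts: the step of a number 33 percentage points higher from compound 1 to compound 3 (beyond the scatter) is real, whereas the step of a number 8 percentage points higher from compound 2 to compound 3 (within the scatter) leaves compound 2 and compound 3 indistinguishable. Compound 4, `CCCCCCCCN(C)C(=O)Cn1cc(Cc2cnc(=O)n(CCO)c2)c(=O)nc1SCc1ccc(F)cc1`, is the next member. It differs from compound 3 in one place: hydroxymethyl in place of carboxy on a saturated chain carbon bound to an aromatic nitrogen.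

Among the compounds with values here, two measured steps bear on this. The step of a number 25 percentage points higher from compound 1 to compound 2 (beyond the scatter) and the step of a number 33 percentage points higher from compound 1 to compound 3 (beyond the scatter) both concern the exchange of the whole group on the saturated chain carbon bound to an aromatic carbon, which compound 4 shares unchanged with compound 3. Within the data shown here, the only step at the place now being varied, the saturated chain carbon bound to an aromatic nitrogen, is a number 8 percentage points higher from compound 2 to compound 3 (within the scatter), which stayed within the scatter although carboxy replaced methyl there. Hydroxymethyl in place of carboxy is a smaller alteration at the same site, so no step beyond the scatter is expected in this assay. For compound 4 the expected step is a number 4 percentage points lower from compound 3 to compound 4 (within the scatter). Compound 4 is therefore estimated at 52%, with a range from 38% to 66%.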

Compound 4, a percentage reported as inhibition, at one concentration (the size of the read-out at that concentration, not a potency): 59%
Compound 4: the middle estimate sits 7 percentage points below what was measured; the range from low to high includes it.
By their numbers in this assay, from the lowest: compound 1; then compounds 2, 3 and 4 (each within the scatter of the next, the first and the last beyond it).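

In this assay the change carboxymethyl to 2-hydroxyethyl gives a number 3 percentage points higher from compound 3 to compound 4 (within the scatter), so among these compounds the carboxy group is not needed to hold the read-out at this level. Hydroxy in place of hydrogen gives the first step beyond the scatter at this place, a number 11 percentage points higher from compound 2 to compound 4 (beyond the scatter), whereas the step from compound 2 to compound 3 stayed within it. The exchange of the whole group on the saturated chain carbon bound to an aromatic carbon now gives a number 36 percentage points higher from compound 1 to compound 4 (beyond the scatter), which adds a third compound above compound 1, and nothing available accounts for these steps.

Still open, on these data alone, is whether an amine, such as aminoethyl, on the saturated chain carbon bound to an aromatic nitrogen would hold this level in this assay. A longer hydroxyalkyl chain or a methyl ether at the same place would test how much the hydroxy hydrogen and the chain length each contribute.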